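The source may report more compounds than this note shows. Statements on the series, on what has been measured and on what is new or still open speak of the compounds shown alone.

Working notes on the series in a functional assay on SKBR cells (Homo sapiens) for cytotoxicity, read by resazurin assay, with a stated time of 72 h; a higher number here means a weaker inhibitor, a lower number a stronger inhibitor. Compound 1 `O=C(/C=C/c1ccc(OCCCCCO[N+](=O)[O-])c(O)c1)OCCCCCO[N+](=O)[O-]` gives 2710 nM. Compound 2 `O=C(/C=C/c1ccc(OCCCCO[N+](=O)[O-])c(O)c1)OCCCCO[N+](=O)[O-]` gives 3230 nM; how the core of compound 2 differs from that of compound 1 is not broken down here. Compound 3 `COc1cc(/C=C/C(=O)OCCCCCO[N+](=O)[O-])ccc1OCCCCCO[N+](=O)[O-]` gives > 50000 nM, which is a limit of the assay (the limit of > 50000 nM in this assay, at which 1 of the 3 values shown sits). The change methyl in place of hydrogen on an oxygen on an aromatic ring made an at least 18-fold higher number from compound 1 to compound 3 (1.26 log units; beyond the scatter). Compound 4 `COc1cc(/C=C/C(=O)OCCCCO[N+](=O)[O-])ccc1OCCCCO[N+](=O)[O-]` carries the same change relative to compound 2, (methyl in place of hydrogen on an oxygen on an aromatic ring), at a place described in the same words. On the strength of an at least 18-fold higher number from compound 1 to compound 3 (1.26 log units; beyond the scatter), the step from compound 2 to compound 4 is expected to be of similar size, a 19-fold higher number from compound 2 to compound 4 (1.27 log units; beyond the scatter), resting on compound 2 at 3230 nM. Compound 4 is therefore estimated at 60000 nM, between 25000 nM and 150000 nM, most likely reported only as a limit.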

Compound 4, half-maximal inhibitory concentration: > 50000 nM
Compound 4 gave a limit, no number (the forecaster's own chance of this, stated with the estimate: 70%); the middle value is on the limit's open side.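

In this assay the change from hydroxy to methoxy carries over to the second core in the same direction and remains large, giving an at least 15-fold higher number from compound 2 to compound 4 (1.18 log units; beyond the scatter). Compound 3 and compound 4 both stand at a limit of the assay, not at a number: the limit of > 50000 nM in this assay, at which 2 of the 4 values shown sit. The result therefore shows that the loss recurs on these two cores, but not how large either step really is or whether the two match: the same change on two cores in this assay, an at least 18-fold higher number (1.26 log units; beyond the scatter) from compound 1 to compound 3 and an at least 15-fold higher number (1.18 log units; beyond the scatter) from compound 2 to compound 4; the limit leaves it open whether they differ.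

The compounds shown leave open how an ethyl group on the same oxygen would read in this assay. They also leave open whether the hydroxy compounds would hold their level with a longer chain than those in compound 1 and compound 2.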